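Sulfonamide series: exchanging the group on the ring nitrogen

A few compounds are considered here, and "the series" means these few. Any claim that something is new, unique, unknown or untested is made for them only; others in the source may bear on it.

Measured compounds:
- compound 1, `O=C(c1ccccn1)N1CCC(NS(=O)(=O)c2cc(S(=O)(=O)c3ccccc3)ccc2C(F)(F)F)CC1`, 60 nM
- compound 2, `N#Cc1cccc(S(=O)(=O)N2CCC(NS(=O)(=O)c3cc(S(=O)(=O)c4ccccc4)ccc3C(F)(F)F)CC2)c1`, 90 nM

Both compounds share a core and differ only in the group on an amine nitrogen in a ring. In an assay on isolated protein for displacement of a labelled ligand from secreted frizzled-related protein 1 (Homo sapiens), read by fluorescence polarization, with a stated time of 30 min (on this read-out higher numbers stand for weaker inhibition and lower numbers for stronger inhibition), compound 1 gives 60 nM and compound 2 gives 90 nM. Among the measured compounds shown here, the one measured step, a 1.5-fold higher number from compound 1 to compound 2 (0.18 log units; within the scatter), is within the scatter. Compound 2 therefore stands at the highest of the two numbers, but its nearest neighbour, compound 1, sits within the scatter of it, so no order between the two can be claimed.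

Compound 3, `O=C(CC1CCNCC1)N1CCC(NS(=O)(=O)c2cc(S(=O)(=O)c3ccccc3)ccc2C(F)(F)F)CC1`, is not yet measured. It differs from compound 2 at the same ring nitrogen: ((piperidin-4-yl)methyl)carbonyl in place of (3-cyanophenyl)sulfonyl on an amine nitrogen in a ring.

For the measured compounds named here, the only step that bears on this position is the one from compound 1 to compound 2, and it was within the scatter. That single step gives no direction for the new group, which differs from both earlier groups in ring type and in what is counted. The expectation is a step of a 1.3-fold higher number from compound 2 to compound 3 (0.12 log units; within the scatter), not clearly beyond the scatter, with a wide range to allow for the larger structural departure.

Compound 3 is estimated at 120 nM, between 35 nM and 450 nM.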

Compound 3, half-maximal inhibitory concentration: 100 nM
Compound 3: middle estimate off by 1.2-fold (0.08 log units), on the high side; the range from low to high includes it.
By their numbers in this assay, from the lowest: compounds 1, 2 and 3 (each within the scatter of the next).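

Compound 3 brings a non-aromatic six-membered ring with one hetero atom and a hydrogen-bond donor to the ring nitrogen, where compound 1 and compound 2 both carry an aromatic ring. In this assay, the change from (3-cyanophenyl)sulfonyl to ((piperidin-4-yl)methyl)carbonyl gives a 1.1-fold higher number from compound 2 to compound 3 (0.05 log units; within the scatter) and, with the carbonyl kept, (piperidin-4-yl)methyl in place of pyridin-2-yl gives a 1.7-fold higher number from compound 1 to compound 3 (0.22 log units; within the scatter) and so, for these three compounds, neither the aromatic ring nor the choice of sulfonyl or carbonyl on this nitrogen separates the numbers beyond the scatter. No measurement is available that would explain this similarity.

It remains open whether any group on this nitrogen can move the number beyond the scatter, and the three groups shown do not settle how much of the group is needed at all. A free ring amine, a small acetyl group, or a longer chain ending in a carboxylic acid would probe this position further.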